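A few compounds are considered here, and "the series" means these few. Any claim that something is new, unique, unknown or untested is made for them only; others in the source may bear on it.

In an assay on HEK293 cells for activation of Kir3.1/Kir3.2 (Homo sapiens), read by thallium flux (a lower number here means a smaller maximal response, a higher number a larger maximal response), compound 2, `Cc1cc(NC(=O)Cn2nnc(-c3ccc(F)cc3)n2)n(C2CCCCC2)n1`, reaches 92%. Compound 1, `CC1(c2cc(NC(=O)Cn3nnc(-c4ccccc4)n3)n(C3CCCCC3)n2)CC1`, is recorded in this assay only as a limit, > 10%. For the measured compounds named here, compound 2 thus holds the only number measured here, while the other entry stands at the limit of > 10% in this assay, at which 1 of the 2 values shown sits. Compound 3, `Cc1cc(NC(=O)Cn2nnc(-c3cccc(C(F)(F)F)c3)n2)n(C2CCCCC2)n1`, differs from compound 2 by 3-(trifluoromethyl)phenyl in place of 4-fluorophenyl on an aromatic carbon. Going by the values given here, no measured pair shows how such a change moves the maximal response, so the step expected in this assay is small, within the usual scatter, with no direction favoured. Compound 3 is therefore expected to give 85%, between 55% and 105%, an estimated step of a number 7 percentage points lower from compound 2 to compound 3 (within the scatter).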

Compound 3, largest response reached (Emax), in percent of the reference or control that the assay uses: 86%
Estimate against measurement, compound 3: 1 percentage points below; measured number inside the range.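

The swap of 4-fluorophenyl for 3-(trifluoromethyl)phenyl on this aromatic carbon gives, in this assay, a number 6 percentage points lower from compound 2 to compound 3 (within the scatter). The position therefore tolerates a group of 10 heavy atoms in place of one of 7, and the two compounds cannot be told apart by their maximal response. Nothing among the data shown accounts for this tolerance. Still open, as far as these compounds go, is whether the response survives on losing the phenyl ring altogether, for example with an amine or a short alkyl chain here, or on adding a carboxylic acid to that ring.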